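The compounds below may be only part of what the source reports. "The series", "measured", "known", "first", "only" and "open" are said of these compounds alone.

Compound 1 `O=C1OCC[C@@H]1NC(=S)SCCOc1cccc2ccccc12`: > 64000 nM
Compound 2 `CC(C)c1ccc(NCC(=O)N[C@H]2CCOC2=O)cc1`: > 64000 nM
Compound 3 `C=CCc1ccc(OCCSC(=S)N[C@H]2CCOC2=O)c(OC)c1`: > 64000 nM

Of the compounds shown here, three have so far been tested in a functional assay on DU-145 cells (Homo sapiens) for antiproliferative activity, read by MTT assay, with a stated time of 72 h (on this read-out higher numbers stand for weaker inhibition and lower numbers for stronger inhibition), and none of them gave a number. The value shown for compound 1 is a limit of the assay, not a measured number. The value shown for compound 2 is likewise a limit of the assay. The value shown for compound 3 is a limit of the assay too. Compound 2 therefore stands exactly where the other two stand, at the limit of > 64000 nM in this assay, at which 3 of the 3 values shown sit, and nothing in these results separates it from compound 1 or compound 3.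

The next compound, compound 4 `O=C(CNc1ccc(F)cc1)N[C@H]1CCOC1=O`, keeps the whole of compound 2 except for one replacement: fluoro in place of isopropyl on an aromatic carbon. Within the data shown here, no pair of measured compounds differs in only one place, so there is no measured step to lean on. Among the measured compounds shown here, with every value so far sitting at the limit, the change from compound 2 to compound 4 is expected to bring no step beyond the usual scatter in this assay, and the most likely outcome is that compound 4 again reaches only the limit. Compound 4 is thus expected at 80000 nM, with a range from 25000 nM to 250000 nM, which would mean an expected step that the limit leaves unreadable from compound 2 to compound 4.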

Compound 4, half-maximal inhibitory concentration: > 64000 nM
Compound 4: a limit, no number; the forecaster's own chance of this, stated with the estimate: 85%; the middle value lies beyond the limit too.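

In this assay compound 4 gives > 64000 nM, which is a limit and not a number. Compound 2 also sits at a limit, so no step can be read between compound 2 and compound 4. The compounds shown leave open how fluoro and isopropyl compare, and whether any of these compounds has a measurable effect: the limit of > 64000 nM in this assay, at which 4 of the 4 values shown sit.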